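Shortening the chain carrying the diethylamino group

This account rests on a few compounds, and the source may have more. Where it says the series, first, only, none or still open, it means among the compounds named here.

Two members of the series have been tested in a functional assay on NCI-H460 cells (Homo sapiens) for cytotoxicity, read by MTT assay, with a stated time of 72 h; on this read-out lower numbers stand for stronger inhibition and higher numbers for weaker inhibition. Compound 1 `CCN(CC)CCCNc1nc(-c2ccc(NC(=O)Nc3ccccc3F)cc2)nc2ccsc12` gives 370 nM. For the measured compounds named here, compound 2 `CCN(CC)CCCNc1nc(-c2ccc(NC(=O)Nc3ccccc3Cl)cc2)nc2ccsc12` gives 200 nM, the lower of the two numbers, although the only step so far, a 1.9-fold lower number from compound 1 to compound 2 (0.27 log units; within the scatter), stays within the scatter, so the two cannot be ordered.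

Compound 3 `CCN(CC)CCNc1nc(-c2ccc(NC(=O)Nc3ccccc3Cl)cc2)nc2ccsc12` remains to be measured. Its difference from compound 2 is diethylamino in place of (diethylamino)methyl on a saturated chain carbon, two bonds along the chain from a nitrogen on an aromatic ring. Going by the values given here, this change sits on the saturated chain, well away from the aromatic carbon where the single measured step was made, so that step, a 1.9-fold lower number from compound 1 to compound 2 (0.27 log units; within the scatter), does not bear on it; nothing else among the measured compounds covers a change in chain length. Among the compounds with values here, with no step to lean on, the working assumption is that removing one chain carbon leaves the read-out in this assay near that of compound 2, with a wide band to reflect the missing evidence. Compound 3 is therefore expected to give about 300 nM in this assay, within 90 nM to 1000 nM, which amounts to an estimated step of a 1.5-fold higher number from compound 2 to compound 3 (0.18 log units; within the scatter).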

Compound 3, half-maximal inhibitory concentration: 320 nM
Beside the measured number, compound 3's estimate is 1.1-fold (0.03 log units) below it; measured number inside the range.
By their numbers in this assay, from the lowest: compounds 2, 3 and 1 (each within the scatter of the next).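

In this assay, going from the (3-(diethylamino)propyl)amino chain to the (2-(diethylamino)ethyl)amino chain gives a 1.6-fold higher number from compound 2 to compound 3 (0.20 log units; within the scatter), so these two chain lengths cannot be ordered on this read-out. For the compounds shown here, this is the first reading at the saturated chain, since the earlier pair differed only in the halogen on an aromatic carbon, and it shows that, with the chloro group kept, this shortening produces no difference that can be told from the scatter. No supporting evidence bears on this result, and the numbers alone cannot say what lies behind it.

The compounds shown cover only these two chain lengths, so it remains open how a longer chain such as 4-(diethylamino)butyl would read, or whether morpholine or pyrrolidine in place of diethylamino would give a step beyond the scatter. Also open, as far as these compounds go, is whether the shorter chain reads the same with fluoro in place of chloro, since the chain change has been seen with the chloro group only.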